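The source may hold more compounds than are shown below. What is called first, only, known or untested is meant among the compounds shown, and "the series" means these compounds.

For the measured compounds named here, of the two numbers so far in an in vitro ADME assay on microsomes from liver (Homo sapiens) for pharmacokinetics, read by LC-MS, with a stated time of 10 min, tested at 1 uM (a lower number here means slower removal, a higher number faster removal of the compound), compound 1 `CC(C)c1ccc(NC(=O)[C@H]2CN(C)C[C@@H]2c2ccc(/C=C/C(=O)Nc3ccccc3N)cc2)cc1` sits at 10 mL/min/kg, and the nearest number, that of compound 2, lies within the scatter of it. Compound 2 `Cc1cccc(NC(=O)[C@H]2CN(C)C[C@@H]2c2ccc(/C=C/C(=O)Nc3ccccc3N)cc2)c1` gives 14 mL/min/kg in this assay; the step of a 1.4-fold higher number from compound 1 to compound 2 (0.15 log units; within the scatter) is within the scatter. Compound 3 `Cc1cc(NC(=O)[C@H]2CN(C)C[C@@H]2c2ccc(/C=C/C(=O)Nc3ccccc3N)cc2)ccc1F` is not yet measured; it differs from compound 1 by 4-fluoro-3-methylphenyl in place of 4-isopropylphenyl on an amide-type nitrogen. Going by the values given here, the one measured step at this amide-type nitrogen, a 1.4-fold higher number from compound 1 to compound 2 (0.15 log units; within the scatter), was small, so in this assay no step beyond the scatter is expected. For compound 3 the expected step is a 1.2-fold higher number from compound 1 to compound 3 (0.08 log units; within the scatter). Compound 3 is estimated at 12 mL/min/kg, range 6 mL/min/kg to 24 mL/min/kg.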

Compound 3, clearance: 15 mL/min/kg
Beside the measured number, compound 3's estimate is 1.3-fold (0.10 log units) below it; low and high end bracket the measured number.
By their numbers in this assay, from the lowest: compounds 1, 2 and 3 (each within the scatter of the next).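

In this assay, exchanging 4-isopropylphenyl for 4-fluoro-3-methylphenyl on the amide-type nitrogen stays within the scatter (a 1.5-fold higher number from compound 1 to compound 3 (0.18 log units; within the scatter)), so a second substituted phenyl at this position fits the first step. The series also now holds a fluoro in place of hydrogen on an aromatic carbon, and this too stays within the scatter (a 1.1-fold higher number from compound 2 to compound 3 (0.03 log units; within the scatter)). Nothing measured bears on why these three numbers stay so close.

Open, on these data alone, is whether a phenyl carrying an amine or a carboxylic acid would leave the scatter. The same question stands for a cyclohexyl group on this nitrogen.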